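Thiophene for Methoxyphenyl: What Cytotoxicity to Expect

This account rests on a few compounds, and the source may have more. Where it says the series, first, only, none or still open, it means among the compounds named here.

Measured so far:
Compound 1, `Cc1ccc(C(=O)NC(=S)N2CCc3c(OCCCCCOc4ccc(Cl)cc4)cccc32)cc1`, reaches only the limit > 50000 nM in an ADME assay on Huh-7 cells (Homo sapiens) for cytotoxicity; on this read-out lower numbers stand for higher toxicity in this test and higher numbers for lower toxicity in this test.
Compound 2, `COc1ccc(C(=O)NC(=S)N2CCc3c(OCCCCCOc4ccc(Cl)cc4)cccc32)cc1`, gives 34400 nM in this assay.

Among the compounds with values here, compound 2 holds the only true number; the value of compound 1 is a limit of the test rather than a number. The step of an at least 1.4-fold lower number from compound 1 to compound 2 (0.16 log units; that floor lies within the scatter) is therefore read against that limit, a point recorded as the limit of > 50000 nM in this assay, at which 1 of the 2 values shown sits, and lies within the usual scatter.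

Compound 3, `O=C(NC(=S)N1CCc2c(OCCCCCOc3ccc(Cl)cc3)cccc21)c1cccs1`, differs from compound 2 by thiophen-2-yl in place of 4-methoxyphenyl on a carbonyl carbon. Within the data shown here, no measured step touches this change: the single step known alters only the methoxy against methyl on an aromatic carbon, and it stayed within the scatter. There is thus no ground in these data to expect movement in this assay beyond the scatter in either direction, and a result at the limit remains possible.

Compound 3 is therefore expected to give about 40000 nM in this assay, between 15000 nM and 100000 nM.

The step of a 1.2-fold higher number from compound 2 to compound 3 (0.07 log units; within the scatter) is estimated to stay within the scatter.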

Compound 3, half-maximal cytotoxic concentration: 10700 nM
Compound 3: the middle estimate sits 3.7-fold (0.57 log units) above what was measured, and the stated range ends above it.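

In this assay, the group on the carbonyl carbon proves able to shift the result beyond the scatter, which the methoxy-for-methyl change did not do: the step is a 3.2-fold lower number from compound 2 to compound 3 (0.51 log units; beyond the scatter), and a lower number here stands for higher toxicity in this test. Set against the 4-methylphenyl group, the same thiophen-2-yl ring gives an at least 4.6-fold lower number from compound 1 to compound 3 (0.66 log units; beyond the scatter), so it sits on the more toxic side of both six-membered aromatic groups shown, though this second step has only a floor for its size. The value of compound 1 is a limit and not a number: the limit of > 50000 nM in this assay, at which 1 of the 3 values shown sits.

The compounds shown do not separate the sulfur atom, the smaller five-membered ring and the loss of the group carried on the six-membered ring, as all three change together in this swap. Furan-2-yl, which keeps the five-membered ring but has oxygen in place of sulfur, and plain phenyl, which keeps the six-membered ring without a methoxy or methyl group, would begin to pull these apart, and a thiophen-2-yl ring carrying a methoxy group would test the third.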